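Extending the Amine Chain by One Carbon

The compounds below may be only part of what the source reports. "The series", "measured", "known", "first", "only" and "open" are said of these compounds alone.

Of the compounds shown here, two have been measured in an assay on HEK293 cells for agonist activity at Toll-like receptor 8 (Homo sapiens), read by reporter gene assay; on this read-out higher numbers stand for an effect only at larger amounts of compound and lower numbers for an effect already at smaller amounts. Compound 1, `CCCCCn1c(N)nc2c(C)cccc21`, gives 1800 nM in this assay. Compound 2, `CCCCNc1nc(N)nc(C)c1I`, gives 1640 nM in this assay; the two values lie within the usual scatter of each other, so neither can be called more potent. Compound 3, `CCCCCNc1nc(N)nc(C)c1I`, differs from compound 2 by methyl in place of hydrogen on a saturated chain carbon, four bonds along the chain from a nitrogen on an aromatic ring. Among the measured compounds shown here, no measured pair shows such a change here, so the step from compound 2 to compound 3 is expected to be small, a 1.3-fold lower number from compound 2 to compound 3 (0.10 log units; within the scatter), not clearly beyond the scatter. Compound 3 is therefore estimated at 1300 nM, with a likely range from 500 nM to 3500 nM.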

Compound 3, half-maximal effective concentration: 3700 nM
Estimate against measurement, compound 3: 2.8-fold (0.45 log units) below, outside the stated range (above it).
By their numbers in this assay, from the lowest: compounds 2 and 1 (each within the scatter of the next); then compound 3.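

Methyl in place of hydrogen on this chain carbon gives a 2.3-fold higher number from compound 2 to compound 3 (0.35 log units; beyond the scatter) and so shows that this chain is sensitive to a single added carbon, since the change goes beyond the usual scatter. The step is modest, but it points towards needing more compound for the same effect, not less. Nothing measured on hand accounts for this shift.

One step gives no trend along the chain. On these data alone, whether a longer chain such as hexyl, or a hydroxyl group at this carbon, would raise or lower the number remains open.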